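Swapping one fluorinated group for another on a shared scaffold

The source may report more compounds than this note shows. Statements on the series, on what has been measured and on what is new or still open speak of the compounds shown alone.

Of the compounds shown here, three have been tested in a functional assay on CWR22R cells (Homo sapiens) for antiproliferative activity, read by propidium iodide staining, with a stated time of 96 h; on this read-out higher numbers stand for weaker inhibition and lower numbers for stronger inhibition. Compound 1, with the structure `CC(O)(CSc1cc(C(F)(F)F)cc(C(F)(F)F)c1)C(=O)Nc1cccc(S(F)(F)(F)(F)F)c1`, gives 4400 nM. Compound 2, with the structure `CC(O)(COc1cccc(S(F)(F)(F)(F)F)c1)C(=O)Nc1cc(C(F)(F)F)cc(C(F)(F)F)c1`, gives 2300 nM, and compound 3, with the structure `CC(O)(COc1cccc(C(F)(F)C(F)(F)F)c1)C(=O)Nc1cc(C(F)(F)F)cc(C(F)(F)F)c1`, gives 4100 nM. All three numbers sit close together, and none of the gaps between them reaches beyond the usual scatter of this kind of measurement.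

Compound 2 and compound 3 differ in a single spot: a group of 7 heavy atoms (2 carbon, 5 fluorine; no ring) in place of a group of 6 heavy atoms (5 fluorine, 1 sulfur; no ring), on an aromatic carbon. This change brought a 1.8-fold higher number from compound 2 to compound 3 (0.25 log units; within the scatter).

Compound 4, with the structure `CC(O)(CSc1cc(C(F)(F)F)cc(C(F)(F)F)c1)C(=O)Nc1cccc(C(F)(F)C(F)(F)F)c1`, has not yet been measured. It is related to compound 1 by the same change: a group of 7 heavy atoms (2 carbon, 5 fluorine; no ring) in place of a group of 6 heavy atoms (5 fluorine, 1 sulfur; no ring), on an aromatic carbon. The surroundings of the change are described in the same words for both pairs, so the two changes can be called the same. The cores of compound 1 and compound 2, however, are not the same, and the difference between the two cores is not broken down here.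

Because compound 2 to compound 3 showed a 1.8-fold higher number from compound 2 to compound 3 (0.25 log units; within the scatter), a step of similar size is expected from compound 1 onward, namely a 1.7-fold higher number from compound 1 to compound 4 (0.23 log units; within the scatter) in this assay. On that basis compound 4 is estimated at 7500 nM in this assay, with a plausible range from 3500 nM to 16000 nM.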

Compound 4, half-maximal inhibitory concentration: 4200 nM
For compound 4 the middle estimate is 1.8-fold (0.25 log units) above the measured one; the range from low to high includes it.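

In this assay, putting 1,1,2,2,2-pentafluoroethyl in place of the group of 5 fluorine atoms on sulfur gave a 1.0-fold lower number from compound 1 to compound 4 (0.02 log units; within the scatter), so on the core of compound 1 this swap leaves no readable mark on the number. Set side by side, the two pairs agree as far as this measurement can tell, so the change can be said to have carried from one core to the other without any detectable difference: the same change on two cores in this assay, a 1.8-fold higher number (0.25 log units; within the scatter) from compound 2 to compound 3 and a 1.0-fold lower number (0.02 log units; within the scatter) from compound 1 to compound 4, 1.9-fold (0.27 log units) apart, within the scatter of two such steps This does not show that the swap has no effect at all, since a small real effect could hide inside the scatter, and two pairs cannot establish a rule for the whole series or predict what would happen on a third core.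

All four compounds carry one of these two fluorinated groups at the site of the change, so the compounds shown leave open how a simple hydrogen, an amine, a carboxylic acid or a longer fluorinated chain would read there. They also leave open whether a larger step would appear with any of these groups, and whether such a step would then stay the same from one core to the other.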